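Cytotoxicity notes: ester to dimethylamino swap

This account rests on a few compounds, and the source may have more. Where it says the series, first, only, none or still open, it means among the compounds named here.

Compound 2 `O=C(OC1CCCCC1)c1ccc(NCc2cncn2Cc2ccc(-c3ccccc3)cc2)cc1-c1ccccc1` was examined in a toxicity assay on NIH3T3 cells (Mus musculus) for cytotoxicity, read by resazurin assay; on this read-out higher numbers stand for an effect only at larger amounts of compound and lower numbers for an effect already at smaller amounts; for compound 2 the result is only a limit, > 10000 nM. Compound 1 `Nc1cc(-c2ccccc2)ccc1Cn1cncc1CNc1ccc(-c2cncs2)c(-c2ccccc2)c1` likewise gives only a limit in this assay, > 1000 nM. For compound 3 `COC(=O)c1ccc(NCc2cncn2Cc2cccc(-c3ccccc3)c2)cc1-c1ccccc1` the entry in this assay is "not determined" (no result reported), with no result reported. Going by the values given here, no step between measured compounds can be drawn from this set; the two limits, the limit of > 1000 nM in this assay, at which 1 of the 3 values shown sits, and (the limit of > 10000 nM in this assay, at which 1 of the 3 values shown sits), are the whole record so far. Compound 4 `CN(C)c1ccc(NCc2cncn2Cc2ccc(-c3ccccc3)cc2)cc1-c1ccccc1` differs from compound 2 by dimethylamino in place of cyclohexyloxycarbonyl on an aromatic carbon. With both measured values sitting at limits, the change is expected to bring nothing beyond the scatter, and a limit is again the likeliest outcome. The half-maximal effective concentration of compound 4 in this assay is estimated at 20000 nM, range 5000 nM to 80000 nM. This estimate means an expected step from compound 2 to compound 4 of a step that the limit leaves unreadable from compound 2 to compound 4, within the scatter.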

Compound 4, half-maximal effective concentration: > 1000 nM
Compound 4: a limit, no number (the forecaster's own chance of this, stated with the estimate: 70%); the middle value lies beyond the limit too.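

Going by these compounds alone, no step from compound 2 to compound 4 can be read in this assay: both results are limits, not numbers. The compounds shown leave open whether dimethylamino in place of cyclohexyloxycarbonyl shifts the half-maximal effective concentration at all.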